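The source may hold more compounds than are shown below. What is called first, only, known or untested is meant among the compounds shown, and "the series" means these compounds.

Compound 1, `COc1ccc(OC)c(/C=C/c2nnc(Nc3ccc(Cl)cc3)o2)c1`, gives in a functional assay on MOLT-4 cells (Homo sapiens) for antiproliferative activity, read by sulforhodamine B assay, with a stated time of 48 h (on this read-out higher numbers stand for weaker inhibition of growth and lower numbers for stronger inhibition of growth), only the assay limit of > 100000 nM. Compound 2, `COc1ccc(OC)c(/C=C/C(=O)N/N=C/c2ccc(Cl)cc2)c1`, likewise gives in this assay only the limit of > 100000 nM. On the numbers shown compound 2 therefore stands at no definite place: it sits at the limit of > 100000 nM in this assay, at which 2 of the 2 values shown sit, together with the other value, and no measured step separates the two. Compound 3, `COc1ccc(OC)c(/C=C/C(=O)N/N=C/c2ccccc2)c1`, differs from compound 2 by hydrogen in place of chloro on an aromatic carbon. Within the data shown here, with no measured step covering this change, no shift beyond the usual scatter is expected in this assay. Compound 3 is expected to give about 100000 nM, somewhere between 30000 nM and 300000 nM. The expected step of a number no higher from compound 2 to compound 3 (the limit leaves the size open) is none beyond the scatter.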

Compound 3, concentration for total growth inhibition: > 100000 nM
Compound 3 ended at the assay's limit (the forecaster's own chance of this, stated with the estimate: 80%); the middle value sits exactly at the limit.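

In this assay compound 2 and compound 3 both stand at the assay limit, so no step can be read from the change of 4-chlorophenyl to phenyl. The compounds shown leave open how strongly any of them inhibits growth and whether that change shifts it at all.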